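This account rests on a few compounds, and the source may have more. Where it says the series, first, only, none or still open, it means among the compounds named here.

Of the compounds shown here, two of one shared core have been measured here, and a third has not. Compound 1 `O=C1O/C(=C\Cn2cc(-c3cc(F)cc(F)c3)nn2)C(OCc2ccccc2)=C1OCc1ccccc1` was tested in a functional assay on SW-620 cells (Homo sapiens) for antiproliferative activity, read by MTT assay, with a stated time of 72 h; a higher number here means a weaker inhibitor, a lower number a stronger inhibitor. In this assay compound 1 gives > 100000 nM, which is a limit of the assay and not a number. Compound 1 therefore stands at the limit of > 100000 nM in this assay, at which 1 of the 2 values shown sits, so only a ceiling of potency is known for it. Compound 2 `O=C1O[C@H]([C@@H](O)Cn2cc(CNS(=O)(=O)c3ccc(Cl)cc3)nn2)C(OCc2ccccc2)=C1OCc1ccccc1` is the other measured member, and in this assay compound 2 gives 18000 nM. Going by the values given here, no step between the two measured compounds is given, and their structures differ in more than one place, so they are read only as two separate values. Compound 3 `O=C1O/C(=C\Cn2cc(-c3cccc(O)c3)nn2)C(OCc2ccccc2)=C1OCc1ccccc1` is the unmeasured one. It differs from compound 1 by 3-hydroxyphenyl in place of 3,5-difluorophenyl on an aromatic carbon, a 3-hydroxyphenyl in place of 3,5-difluorophenyl on an aromatic carbon. Among the compounds with values here, no measured step guides this change, and compound 1 is known only as a limit. Compound 3 is expected to give 80000 nM in this assay, with a range from 20000 nM to 300000 nM. That estimate means a step of an at least 1.2-fold lower number from compound 1 to compound 3 (0.09 log units; that floor lies within the scatter), expected to be small or none beyond the scatter, with a fair chance that only a limit is reported again.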

Compound 3, half-maximal inhibitory concentration: 69800 nM
Estimate against measurement, compound 3: 1.1-fold (0.06 log units) above; the range from low to high includes it.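

In this assay, putting 3-hydroxyphenyl in place of 3,5-difluorophenyl on the aromatic carbon of the five-membered ring amounts to an at least 1.4-fold lower number from compound 1 to compound 3 (0.15 log units; that floor lies within the scatter). Going by these compounds alone, with compound 3 at 69800 nM, this position now has a true number for the first time. The size of the step has only a floor, and the step does not show whether the change from 3,5-difluorophenyl to 3-hydroxyphenyl alters potency beyond the scatter. Compound 1 is known only as a limit of the assay, and that limit fixes how little of the step can be read: the limit of > 100000 nM in this assay, at which 1 of the 3 values shown sits.

As far as these compounds go, what remains open is whether the hydroxyl group matters in itself or whether the loss of the two fluorine atoms is what counts, a question that an unsubstituted phenyl or a methoxyphenyl at the same place would help to separate. From the compounds shown here alone, it is also open how a phenyl ring carrying an amine or a carboxylic acid would read there, and whether any group at this place can bring the shared core much below the value of compound 3.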